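Swapping the nitrile for an ester chain on the amine

The source may hold more compounds than are shown below. What is called first, only, known or untested is meant among the compounds shown, and "the series" means these compounds.

Compound 1 `N#CCN(Cc1ccccc1)Cc1ccc2ccccc2c1` gives 0% in an assay on HEK293 cells for binding affinity to Substance-K receptor (Rattus norvegicus), read by FRET, tested at 10 uM (on this read-out higher numbers stand for more inhibition at the one concentration tested (going by the name of the read-out) and lower numbers for less inhibition), and it sits level with the other two measured compounds. Compound 2 `N#CCN(Cc1ccc(Br)cc1)Cc1ccc2ccccc2c1` gives 0% in this assay, and compound 3 `COc1ccc(CN(CC#N)Cc2ccc3ccccc3c2)cc1` gives 0%. The steps of no change at the digits printed from compound 1 to compound 2 (within the scatter), no change at the digits printed from compound 1 to compound 3 (within the scatter) and no change at the digits printed from compound 2 to compound 3 (within the scatter) all stay flat. Compound 4 `CCOC(=O)CCCCN(Cc1ccccc1)Cc1ccc2ccccc2c1` differs from compound 1 by 3-(ethoxycarbonyl)propyl in place of cyano on a saturated chain carbon bound to an amine nitrogen. Among the measured compounds shown here, none of the measured steps changes that part of the molecule; they only alter a substituent on an aromatic carbon, and every one of them left the read-out unchanged. For the measured compounds named here, no measured step therefore bears directly on this change, and the whole series so far shows no inhibition. The step from compound 1 to compound 4 is expected to be no change at the digits printed from compound 1 to compound 4 (within the scatter). Compound 4 is estimated at 0%, with a range from 0% to 10%.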

Compound 4, a percentage reported as inhibition, at one concentration (the size of the read-out at that concentration, not a potency): 0%
Estimate against measurement, compound 4: no gap at the digits printed; measured number inside the range.
By their numbers in this assay, from the lowest: compounds 1, 2, 3 and 4 (each within the scatter of the next).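

In this assay, replacing cyano with 3-(ethoxycarbonyl)propyl on the saturated chain carbon bound to the amine nitrogen gives no change at the digits printed from compound 1 to compound 4 (within the scatter). This position therefore joins the aromatic substituents as a place where a change left the read-out flat, even with an entering group of more heavy atoms than cyano. No evidence at hand explains this flat result. Going by these compounds, whether an amine or a carboxylic acid on this chain would give any inhibition stays open. On these data alone, with all four compounds level, which parts of the molecule matter for this receptor also stays open.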